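A few compounds are considered here, and "the series" means these few. Any claim that something is new, unique, unknown or untested is made for them only; others in the source may bear on it.

Compound 1 `CCc1cc(=O)c2ccc(OCc3cccc(C(F)(F)F)c3)c(C)c2o1` gives > 27600 nM in a functional assay on DU-145 cells (Homo sapiens) for antiproliferative activity, read by sulforhodamine B assay, with a stated time of 72 h (on this read-out higher numbers stand for weaker inhibition of growth and lower numbers for stronger inhibition of growth), which is a limit of the assay rather than a number.
Compound 2 `CCc1cc(=O)c2ccc(OCc3cccc(C#N)c3)c(C)c2o1` gives > 31300 nM in this assay, again only a limit.

Among the compounds with values here, compound 1 therefore stands at a limit, as does the only other value shown, so its place among real numbers cannot be fixed. Within the data shown here, the single measured step, a step that the two limits leave unreadable from compound 1 to compound 2, stays unreadable because the limit of > 27600 nM in this assay, at which 1 of the 2 values shown sits, and the limit of > 31300 nM in this assay, at which 1 of the 2 values shown sits, hold both values. Compound 3 `CCc1oc2c(C)c(OCc3cccc(C(F)(F)F)c3)ccc2c(=O)c1Br` differs from compound 1 by bromo in place of hydrogen on an aromatic carbon. Among the measured compounds shown here, no measured step bears on this change. Compound 3 is thus expected to remain near the limit, with an estimated 30000 nM (range 5000 nM to 100000 nM), the expected step that the limit leaves unreadable from compound 1 to compound 3 being none beyond the scatter.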

Compound 3, concentration for 50% growth inhibition: > 22600 nM
Compound 3 was reported as a limit; the forecaster's own chance of this, stated with the estimate: 70%; the middle value is on the limit's open side.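

Within the data shown here, compound 3 gives > 22600 nM in this assay, which is a limit of the assay, so no step from compound 1 to compound 3 can be read. The compounds shown leave open whether bromo in place of hydrogen changes growth inhibition at all.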